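The source may hold more compounds than are shown below. What is called first, only, known or untested is meant among the compounds shown, and "the series" means these compounds.

Values in a functional assay on cells (Renal cancer cell line, Homo sapiens) for cytotoxicity, read by sulforhodamine B assay, with a stated time of 48 h; a higher number here means a weaker inhibitor of growth, a lower number a stronger inhibitor of growth:
Compound 1 `COc1ccc2c(c1)/C(=C/c1c(-c3ccncc3)nc3sccn13)C(=O)N2C`: 65500 nM
Compound 2 `COc1cc2c(cc1C)NC(=O)/C2=C/c1c(OC)nc2sc(C)cn12`: 58900 nM
Compound 3 `COc1nc2sc(C)cn2c1C=C1C(=O)N(C)c2ccccc21`: 70600 nM

Compound 2, at 58900 nM, lies within the scatter of both compound 1 and compound 3, so the three values give no order. For the measured compounds named here, no measured pair differs in one place only, so no direct step is available for the change at hand. Compound 4 `COc1ccc2c(c1)/C(=C\c1c(OC)nc3sc(C)cn13)C(=O)N2` differs from compound 2 by hydrogen in place of methyl on an aromatic carbon. Compound 1 at 65500 nM and compound 3 at 70600 nM stay close despite differing in several places, so no shift beyond the scatter is expected in this assay. The expected step of a 1.0-fold higher number from compound 2 to compound 4 (0.01 log units; within the scatter) has no clear direction. The estimate for compound 4 is 60000 nM, with a range of 35000 nM to 95000 nM.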

Compound 4, concentration for total growth inhibition: 61800 nM
For compound 4 the middle estimate is 1.0-fold (0.01 log units) below the measured one; measured number inside the range.
By their numbers in this assay, from the lowest: compounds 2, 4, 1 and 3 (each within the scatter of the next).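

In this assay, for the compounds shown here, hydrogen in place of methyl on an aromatic carbon, ortho to a methoxy group, gives a 1.0-fold higher number from compound 2 to compound 4 (0.02 log units; within the scatter) and is the first single-place comparison. At this position, the methyl group can therefore be lost with no change beyond the scatter, at least in the setting of compound 2. No supporting data bear on why this step is so small. The compounds shown leave open whether an amine or a carboxylic acid on this carbon would move the number.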